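The compounds below may be only part of what the source reports. "The series", "measured", "known", "first", "only" and "open" are said of these compounds alone.

Compound 1 `CC(Sc1nnc(-c2ccncc2)s1)C(=O)NCc1ccccc1Cl`: > 50000 nM
Compound 2 `O=C(CCSc1nnc(-c2ccncc2)s1)Nc1ccc(Cl)cc1`: 7260 nM
Compound 3 `CC(Sc1nnc(-c2ccncc2)s1)C(=O)NCc1ccccc1`: > 50000 nM

In an ADME assay on HepG2 cells (Homo sapiens) for cytotoxicity, with a stated time of 3 days (on this read-out lower numbers stand for higher toxicity in this test and higher numbers for lower toxicity in this test), compound 2 stands alone: it gives the only number shown. The value of compound 1 is a limit of the assay. The value of compound 3 is likewise a limit, so that two of three results sit at the limit of > 50000 nM in this assay, at which 2 of the 3 values shown sit. Compound 4 `O=C(CCSc1nnc(-c2ccncc2)s1)NCc1ccccc1` has not been measured; it differs from compound 2 by benzyl in place of 4-chlorophenyl on an amide-type nitrogen. For the measured compounds named here, the one measured step, a step that the two limits leave unreadable from compound 1 to compound 3, touches the loss of chlorine but its size cannot be read from two limits. Since both compounds that carry a benzyl on the amide nitrogen, compound 1 and compound 3, sit at the limit of > 50000 nM in this assay, at which 2 of the 3 values shown sit, compound 4 is expected to move toward lower toxicity, by a 4.8-fold higher number from compound 2 to compound 4 (0.68 log units; beyond the scatter). Compound 4 is therefore estimated at 35000 nM, between 10000 nM and 90000 nM.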

Compound 4, half-maximal cytotoxic concentration: 14000 nM
Compound 4: middle estimate off by 2.5-fold (0.40 log units), on the high side; low and high end bracket the measured number.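

In this assay, benzyl in place of 4-chlorophenyl on the amide-type nitrogen gives a 1.9-fold higher number from compound 2 to compound 4 (0.29 log units; within the scatter). For the compounds shown here, this is the first readable step at this position, and it does not separate the two compounds beyond the scatter. Compound 4 also shows that benzyl on this nitrogen does not by itself bring a compound to the limit: the limit of > 50000 nM in this assay, at which 2 of the 4 values shown sit.

The compounds shown leave open whether a carboxylic acid or an amine in place of benzyl on this nitrogen would move the number beyond the scatter.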